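Replacing pyridin-4-yl with methyl on the shared core

The compounds below may be only part of what the source reports. "The series", "measured", "known", "first", "only" and "open" are said of these compounds alone.

In a functional assay on A549 cells (Homo sapiens) for inhibition, read by MTT assay, with a stated time of 72 h (on this read-out higher numbers stand for weaker inhibition and lower numbers for stronger inhibition), compound 1 `CC(C)(C)n1cc2c(n1)C(=O)CC1(CCN(C(=O)c3cc(-c4ccccc4Cl)nc4ccccc34)CC1)O2` gives 2180 nM and compound 2 `CC(C)(C)n1cc2c(n1)C(=O)CC1(CCN(C(=O)c3cc(-c4ccncc4)nc4ccccc34)CC1)O2` gives 550 nM as the lower of the two numbers. Compound 3 `Cc1cc(C(=O)N2CCC3(CC2)CC(=O)c2nn(C(C)(C)C)cc2O3)c2ccccc2n1` keeps the shared core but carries methyl in place of pyridin-4-yl on an aromatic carbon next to the ring nitrogen (methyl in place of pyridin-4-yl on an aromatic carbon). Among the compounds with values here, only one measured step bears on this position, and it is modest and beyond the scatter (a 4.0-fold lower number from compound 1 to compound 2 (0.60 log units; beyond the scatter)). Within the data shown here, it shows that the number in this assay responds to the group placed here, but no measured compound carries a small group at this position. A step of similar size toward a higher number is therefore expected, with wide uncertainty in both size and direction. The expected change is (a 2.7-fold higher number from compound 2 to compound 3 (0.44 log units; beyond the scatter)). For compound 3 the estimate is 1500 nM (expected range 500 nM to 4500 nM).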

Compound 3, half-maximal inhibitory concentration: > 10000 nM
Compound 3: no number, only a limit; the forecaster's own chance of this, stated with the estimate: 8%; at least 6.6-fold (0.82 log units) between middle value and limit.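

In this assay compound 3 gives a limit of the assay and not a number: the limit of > 10000 nM in this assay, at which 1 of the 3 values shown sits. Even so, exchanging pyridin-4-yl for methyl gives an at least 18-fold higher number from compound 2 to compound 3 (1.25 log units; beyond the scatter), a large step, and exchanging 2-chlorophenyl for methyl gives an at least 4.5-fold higher number from compound 1 to compound 3 (0.66 log units; beyond the scatter). Within the data shown here, the earlier pair showed only that the number moves from one ring-bearing group to another, whereas these steps show that, among the three compounds, the two with an aromatic ring at this position give the lower numbers and the one with methyl, which has no ring, does not.

Going by these compounds, how far the true value of compound 3 lies past its limit stays open. So does whether the aromatic ring or simply the larger count of heavy atoms matters here, a question that a longer chain such as n-butyl or a saturated ring such as piperidin-4-yl at this position could address.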